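A few compounds are considered here, and "the series" means these few. Any claim that something is new, unique, unknown or untested is made for them only; others in the source may bear on it.

Measured compounds in an ADME assay on HEL cells (Homo sapiens) for cytotoxicity, with a stated time of 3 days; on this read-out lower numbers stand for higher toxicity in this test and higher numbers for lower toxicity in this test:
compound 1 `CCC1(Cc2ccccc2)OS(=O)(=O)C=C1OCCCCc1ccccc1`, value 99000 nM
compound 2 `CCC1(Cc2ccccc2)OS(=O)(=O)C=C1OCC#N`, reported only as a limit of this assay, > 200000 nM
compound 3 `CCC1(Cc2ccccc2)OS(=O)(=O)C=C1OC`, reported only as a limit of this assay, > 200000 nM

Compound 3 thus stands at the limit of > 200000 nM in this assay, at which 2 of the 3 values shown sit, so its position is known only as a limit and not as a number. Going by the values given here, compound 1 is the one member with a value inside the measured range.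

Compound 4 `CCC1(Cc2ccccc2)OS(=O)(=O)C=C1OCc1ccc(Cl)c(Cl)c1` differs from compound 3 by 3,4-dichlorophenyl in place of hydrogen on a saturated chain carbon bound to an oxygen on an unsaturated carbon.

Among the compounds with values here, two measured steps bear on this. From compound 1 to compound 3 the number rose by an at least 2.0-fold higher number from compound 1 to compound 3 (0.30 log units; that floor lies within the scatter), and from compound 1 to compound 2 by an at least 2.0-fold higher number from compound 1 to compound 2 (0.30 log units; that floor lies within the scatter); both only reach a limit and the floors lie within the scatter. The reverse of the first step, putting an aromatic ring back onto that carbon, is the nearest analogue of the change to compound 4. The direction expected in this assay is therefore a lower number, of a size that the limits leave poorly defined, with a real chance that compound 4 again reaches only the limit.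

Compound 4 is expected at 100000 nM, between 35000 nM and 200000 nM, a step of an at least 2.0-fold lower number from compound 3 to compound 4 (0.30 log units; that floor lies within the scatter).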

Compound 4, half-maximal cytotoxic concentration: 36700 nM
The estimate for compound 4 lay 2.7-fold (0.44 log units) above the measured number; measured number inside the range.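

In this assay, going by these compounds alone, 3,4-dichlorophenyl in place of hydrogen on a saturated chain carbon bound to an oxygen on an unsaturated carbon gives an at least 5.4-fold lower number from compound 3 to compound 4 (0.73 log units; beyond the scatter) and thus the first change at this position that clearly exceeds the scatter, and 3,4-dichlorophenyl in place of cyano gives the same floor with an at least 5.4-fold lower number from compound 2 to compound 4 (0.73 log units; beyond the scatter) as its step. The read-out also separates the two substituents that carry an aromatic ring, since 3,4-dichlorophenyl in place of 3-phenylpropyl gives a 2.7-fold lower number from compound 1 to compound 4 (0.43 log units; beyond the scatter) so that a ring alone does not fix the number, and compound 4 has the lowest number of the four. The steps from compound 2 and compound 3 are only floors because both compounds sit at a limit of the assay: the limit of > 200000 nM in this assay, at which 2 of the 4 values shown sit.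

The step between compound 2 and compound 3 cannot be read, so those two compounds cannot be ordered. Open too, going by these compounds, is whether the lower number follows the two chlorines or the ring itself, and how an unsubstituted phenyl, an amine or a carboxylic acid at this carbon would read.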